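Hydroxy to halogen exchange: cytotoxicity working notes

A few compounds are considered here, and "the series" means these few. Any claim that something is new, unique, unknown or untested is made for them only; others in the source may bear on it.

Measured compounds:
- compound 1 `Cn1nc(-c2nnc(-c3ccc(O)cc3)o2)c2ccccc21`; in an ADME assay on L02 cells (Homo sapiens) for cytotoxicity, read by MTT assay, with a stated time of 72 h (a higher number here means a weaker inhibitor, a lower number a stronger inhibitor), compound 1 gives > 100000 nM
- compound 2 `Cn1nc(-c2nnc(-c3ccc(Cl)cc3)o2)c2ccccc21`; in this assay compound 2 gives > 100000 nM

Compound 1 carries only a limit in this assay, not a number. Compound 2 likewise reaches only a limit there. Both values sit at the limit of > 100000 nM in this assay, at which 2 of the 2 values shown sit, so the step that the two limits leave unreadable from compound 1 to compound 2 cannot be read in size; it is chloro in place of hydroxy on an aromatic carbon.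

Compound 3 `Cn1nc(-c2nnc(-c3ccc(Br)cc3)o2)c2ccccc21` is not yet measured. It differs from compound 1 by bromo in place of hydroxy on an aromatic carbon. Among the compounds with values here, the only measured step that bears on it is the one from compound 1 to compound 2, which the two limits leave unreadable; the bromo exchange is of the same kind at the same place. No step beyond the scatter is therefore expected in this assay, and the most likely outcome is again a limit. Compound 3 is estimated at 100000 nM, with a range of 30000 nM to 300000 nM. The expected step is a number no higher from compound 1 to compound 3 (the limit leaves the size open).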

Compound 3, half-maximal inhibitory concentration: > 100000 nM
Compound 3 ended at the assay's limit (the forecaster's own chance of this, stated with the estimate: 85%); the middle value lies on the limit itself.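

In this assay compound 3 gives > 100000 nM, which is a limit and not a number. No step among compound 1, compound 2 and compound 3 can be read in size: the limit of > 100000 nM in this assay, at which 3 of the 3 values shown sit.

The compounds shown leave open whether hydroxy, chloro or bromo at this place makes any difference to cytotoxicity, as none of them gives a number.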